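Methoxy in Place of Fluoro: What to Expect for Compound 4

A few compounds are considered here, and "the series" means these few. Any claim that something is new, unique, unknown or untested is made for them only; others in the source may bear on it.

Three compounds have been measured in a functional assay on MCF7 cells (Homo sapiens) for cytotoxicity, read by MTT assay, with a stated time of 72 h; a lower number here means that less compound is tolerated, a higher number that more compound is tolerated:

Compound 1 `N#C[Se]c1ccc(NC(=O)OCc2ccc([N+](=O)[O-])cc2)cc1` gives 69500 nM.
Compound 2 `N#C[Se]c1ccc(NC(=O)Oc2ccc(F)cc2)cc1` gives 65700 nM.
Compound 3 `N#C[Se]c1ccc(NC(=O)OCc2ccccc2)cc1` gives 68900 nM.

The three numbers lie within the usual scatter of one another, so compound 2 cannot be set apart from compound 1 or compound 3. Compound 4 `COc1ccc(OC(=O)Nc2ccc([Se]C#N)cc2)cc1` differs from compound 2 by methoxy in place of fluoro on an aromatic carbon. For the measured compounds named here, the only step measured so far, a 1.0-fold lower number from compound 1 to compound 3 (0.00 log units; within the scatter), also changed a group on the outer ring and left the number unchanged, and no measured step tests methoxy itself. The change from compound 2 to compound 4 is therefore expected to stay within the scatter, as a 1.0-fold higher number from compound 2 to compound 4 (0.01 log units; within the scatter). For compound 4 the estimate is 67000 nM, with a range from 34000 nM to 134000 nM.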

Compound 4, concentration lethal to 50% of the cells: 74100 nM
Beside the measured number, compound 4's estimate is 1.1-fold (0.04 log units) below it; measured number inside the range.
By their numbers in this assay, from the lowest: compounds 2, 3, 1 and 4 (each within the scatter of the next).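

In this assay, methoxy in place of fluoro gives a 1.1-fold higher number from compound 2 to compound 4 (0.05 log units; within the scatter). For the compounds shown here, this is the first step to change the group on this aromatic carbon, para to a large group, and it shows that replacing fluoro with methoxy, which adds a hydrogen-bond acceptor, does not move the number beyond the scatter. No measurement shown here offers a reason for this result.

On these data alone, whether an amine or a carboxylic acid at this position would move the number beyond the scatter remains open. The same question stands for a longer chain, such as butoxy.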